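This account rests on a few compounds, and the source may have more. Where it says the series, first, only, none or still open, it means among the compounds named here.

Compound 1 `COC(=O)CNC(=O)NCc1ccc(C(=O)N2CCCCc3ccccc32)cc1C`: 37 nM
Compound 2 `Cc1cc(C(=O)N2CCCCc3ccccc32)ccc1CNC(=O)NCC(=O)N(C)C`: 58 nM

In a functional assay on HEK293 cells for agonist activity at Vasopressin V2 receptor (Homo sapiens), read by a luciferase reporter and cAMP accumulation (a higher number here means that more compound is needed for the effect, a lower number that less compound is needed), compound 1 gives the lower of the two numbers, yet the step of a 1.6-fold higher number from compound 1 to compound 2 (0.20 log units; within the scatter) stays within the scatter. Compound 3 `Cc1cc(C(=O)N2CCCCc3ccccc32)ccc1CNC(=O)N1CCC[C@@H]1C(=O)N(C)C` differs from compound 1 in one place: 2-(dimethylcarbamoyl)pyrrolidin-1-yl in place of ((methoxycarbonyl)methyl)amino on a carbonyl carbon. Among the measured compounds shown here, the only measured step that touches this change is a 1.6-fold higher number from compound 1 to compound 2 (0.20 log units; within the scatter), which also brought in a dimethylcarbamoyl group; the ring closure itself has no measured counterpart. A step of a 1.5-fold higher number from compound 1 to compound 3 (0.17 log units; within the scatter) is therefore expected, nothing beyond the scatter. Compound 3 is estimated at 55 nM, in the range 15 nM to 200 nM.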

Compound 3, half-maximal effective concentration: 380 nM
Beside the measured number, compound 3's estimate is 6.9-fold (0.84 log units) below it, and the stated range ends below it.
By their numbers in this assay, from the lowest: compounds 1 and 2 (each within the scatter of the next); then compound 3.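

At this carbonyl carbon, the dimethylcarbamoyl group alone does not explain the rise, since it is present in both compounds of the step of a 6.6-fold higher number from compound 2 to compound 3 (0.82 log units; beyond the scatter). What sets that step apart is the pyrrolidine ring with its defined stereocentre and the absence of a hydrogen-bond donor, and the wider step a 10-fold higher number from compound 1 to compound 3 (1.01 log units; beyond the scatter) shows the same rise against the ester. Nothing available gives a reason for this loss. The compounds shown leave open whether the ring or the lost amide hydrogen matters more, which an open-chain N-methyl glycine amide could separate, and how the mirror-image pyrrolidine would behave.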